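The source may hold more compounds than are shown below. What is called first, only, known or untested is meant among the compounds shown, and "the series" means these compounds.

Compound 2 `COc1cc(F)ccc1N1C(=O)CSC1c1cccc(C(=O)NCCCCc2ccccc2)c1` gives 94% in a functional assay on HOS-TE85 cells (Homo sapiens) for inhibition, read by CCK-8 assay, with a stated time of 72 h, tested at 1 uM; a lower number here means less inhibition, a higher number more inhibition at the concentration tested (going by the name of the read-out). Among the compounds with values here, compound 1 `O=C(NCCCCc1ccccc1)c1cccc(C2SCC(=O)N2c2ccccc2)c1` gives 96% in this assay; the two numbers are not separated beyond the scatter, so compound 2 stands level with the only other number known. Compound 3 `CC(F)(F)c1cccc(N2C(=O)CSC2c2cccc(C(=O)NCCCCc3ccccc3)c2)c1` is not yet measured. It differs from compound 2 as a group of 10 heavy atoms (8 carbon, 2 fluorine; one six-membered aromatic ring of carbon only) in place of a group of 9 heavy atoms (7 carbon, 1 oxygen, 1 fluorine; one six-membered aromatic ring of carbon only), on an amide-type nitrogen in a ring. Within the data shown here, the one step known at this position is a number 2 percentage points lower from compound 1 to compound 2 (within the scatter), which lies within the scatter. A step of the same kind is expected here, as a number 1 percentage points lower from compound 2 to compound 3 (within the scatter), with no change beyond the scatter. Compound 3 is therefore expected to give 93% in this assay, within 80% to 100%.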

Compound 3, a percentage reported as inhibition, at one concentration (the size of the read-out at that concentration, not a potency): 93%
Beside the measured number, compound 3's estimate shows no gap at the digits printed; measured number inside the range.
By their numbers in this assay, from the lowest: compounds 3, 2 and 1 (each within the scatter of the next).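

In this assay a second replacement at the amide-type nitrogen leaves the number level: the 4-fluoro-2-methoxyphenyl group giving way to the group with 10 heavy atoms gives a number 1 percentage points lower from compound 2 to compound 3 (within the scatter) and 1,1-difluoroethyl in place of hydrogen on an aromatic carbon gives a number 3 percentage points lower from compound 1 to compound 3 (within the scatter) overall. The entering group counts no hydrogen-bond acceptor against one in the group it replaces, without a change beyond the scatter. No measurement here explains this level result.

On these data alone, whether an amine or a carboxylic acid on this aromatic ring would hold the number stays open, as does any ranking of these three compounds at a lower concentration.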